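The source may hold more compounds than are shown below. What is called first, only, known or untested is meant among the compounds shown, and "the series" means these compounds.

In a functional assay on IMR-32 cells (Homo sapiens) for antiproliferative activity, read by MTT assay (a higher number here means a weaker inhibitor, a lower number a stronger inhibitor), compound 1 `Cc1c(-n2cc(COc3ccc(/C=C/C(=O)c4cc5c(cc4O)OC(C)(C)CC5)cc3)nn2)cccc1[N+](=O)[O-]` gives "not active" (no number reported), so it offers no single number to start from. Among the compounds with values here, compound 3 `CCc1ccccc1-n1cc(COc2ccc(/C=C/C(=O)c3ccc4c(c3O)CCC(C)(C)O4)cc2)nn1` likewise gives "not active" (no number reported), and the only number in this small set belongs to compound 2 `COc1ccc(-n2cc(COc3ccc(/C=C/C(=O)c4ccc5c(c4O)CCC(C)(C)O5)cc3)nn2)c([N+](=O)[O-])c1`, at 132000 nM. Compound 4 `CC1(C)CCc2cc(C(=O)/C=C/c3ccc(OCc4cn(Cc5ccc([N+](=O)[O-])cc5)nn4)cc3)c(O)cc2O1` is still unmeasured. It differs from compound 1 in one group, with 4-nitrobenzyl in place of 2-methyl-3-nitrophenyl on an aromatic nitrogen. Within the data shown here, without a number for compound 1, no step can be sized, but no large gain in this assay is expected. The expectation is that activity stays weak, in the range of compound 2 at 132000 nM, or that again no number is obtained. For compound 4, the estimated value is 90000 nM, with an expected range of 25000 nM to 250000 nM.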

Compound 4, half-maximal inhibitory concentration: 108000 nM
Estimate against measurement, compound 4: 1.2-fold (0.08 log units) below; the measured number falls inside the stated range.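

Within the data shown here, with no single number for compound 1 in this assay no step to compound 4 can be read. From the compounds shown here alone, whether 4-nitrobenzyl in place of 2-methyl-3-nitrophenyl shifts activity remains open. Nothing shown explains the result of compound 4.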